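Fluoro for bromo on compound 3

A few compounds are considered here, and "the series" means these few. Any claim that something is new, unique, unknown or untested is made for them only; others in the source may bear on it.

In an ADME assay on HCT-116 cells (Homo sapiens) for antiproliferative activity (a higher number here means a weaker inhibitor, a lower number a stronger inhibitor), compound 1 `COc1ccc(C(C)=O)cc1COc1ccc(Cl)cc1` gives 39000 nM and compound 3 `COc1ccc(C(N)=O)cc1/C=C/c1ccc(Br)cc1` gives 22000 nM. These two values lie within the scatter of each other, so compound 3 sits level with compound 1 among the numeric results.

Compound 2 `COc1ccc(C(N)=O)cc1COc1ccc(Cl)c(C)c1` reads > 50000 nM, which is a limit of the assay and not a number.

The next entry is compound 4 `COc1ccc(C(N)=O)cc1/C=C/c1ccc(F)cc1`, which has fluoro in place of bromo on an aromatic carbon, para to a large group. For the measured compounds named here, no measured pair isolates a change of this kind, so the size of the step has no direct precedent. The expectation therefore starts from compound 3 at 22000 nM and allows only a small drift toward a higher number, not clearly beyond the scatter. The expected change is a 1.4-fold higher number from compound 3 to compound 4 (0.13 log units; within the scatter).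

For compound 4 the estimated value in this assay is 30000 nM, with an expected range of 14000 nM to 50000 nM.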

Compound 4, half-maximal inhibitory concentration: 24000 nM
The estimate for compound 4 lay 1.3-fold (0.10 log units) above the measured number, within the range that was stated.
By their numbers in this assay, from the lowest: compounds 3, 4 and 1 (each within the scatter of the next). At a limit, above all of these: compound 2.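

In this assay, for the compounds shown here, the first change confined to a single place gives a 1.1-fold higher number from compound 3 to compound 4 (0.04 log units; within the scatter). On this aromatic carbon, para to a large group, fluoro and bromo therefore cannot be told apart. The earlier compounds shown here differ from one another in more than one place, so they could not show this for any single position.

Going by these compounds, whether a different kind of group on this carbon, such as an amine, a carboxylic acid or a longer chain, would separate from these two halogens remains open, as does the contribution of the other places on the shared core. Any such comparison would also have to stay within a readable range that ends at a ceiling: the limit of > 50000 nM in this assay, at which 1 of the 4 values shown sits.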